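Adding 4-chlorophenyl to the ring nitrogen of compound 2

This account rests on a few compounds, and the source may have more. Where it says the series, first, only, none or still open, it means among the compounds named here.

In a functional assay on A-375 cells (Homo sapiens) for antiproliferative activity, read by MTT assay, with a stated time of 72 h (a higher number here means a weaker inhibitor, a lower number a stronger inhibitor), compound 1 (`O=C1COc2ccc(-c3cccc(NS(=O)(=O)c4ccc(F)cc4)c3)cc2N1`) gives 20100 nM and compound 2 (`COc1ncc(-c2ccc3c(c2)NC(=O)CO3)cc1NS(=O)(=O)c1ccc(F)cc1`) gives 26300 nM with the two values within the scatter of each other. Compound 3 (`O=C1COc2ccc(-c3cnc(Cl)c(NS(=O)(=O)c4ccc(F)cc4)c3)cc2N1`) reads > 40000 nM as a limit of the assay. Compound 4 (`COc1ncc(-c2ccc3c(c2)N(c2ccc(Cl)cc2)C(=O)CO3)cc1NS(=O)(=O)c1ccc(F)cc1`) carries 4-chlorophenyl in place of hydrogen on an amide-type nitrogen in a ring. Among the measured compounds shown here, the one measured step (an at least 1.5-fold higher number from compound 2 to compound 3 (0.18 log units; that floor lies within the scatter)) is chloro in place of methoxy on an aromatic carbon. It leaves that nitrogen untouched and gives no size for this change. A sizeable but uncertain move to a lower number is therefore expected in this assay as an estimated step (an 8.8-fold lower number from compound 2 to compound 4 (0.94 log units; beyond the scatter)). For compound 4 the estimate is 3000 nM with an expected range (400 nM to 20000 nM).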

Compound 4, half-maximal inhibitory concentration: 24100 nM
Estimate against measurement, compound 4: 8.0-fold (0.90 log units) below; the whole stated range lies below it.
By their numbers in this assay, from the lowest: compounds 1, 4 and 2 (each within the scatter of the next). At a limit, above all of these: compound 3.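

The step of a 1.1-fold lower number from compound 2 to compound 4 (0.04 log units; within the scatter), read in this assay, shows that the amide-type nitrogen in a ring can carry 4-chlorophenyl in place of hydrogen without a readable change. Among the compounds shown here, the earlier compounds all left this nitrogen untouched, so this is the first reading at this position, and a whole six-membered aromatic ring there leaves compound 4 level with compound 2. Nothing shown bears on a cause for this flat step.

Going by these compounds, whether a small alkyl group such as methyl, or a chain ending in an amine or a carboxylic acid, would read the same on that nitrogen remains open. On these data alone, a phenyl ring without the chlorine also remains open.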